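A few compounds are considered here, and "the series" means these few. Any claim that something is new, unique, unknown or untested is made for them only; others in the source may bear on it.

Cytotoxicity in an ADME assay on RAW264.7 cells (Mus musculus) for cytotoxicity, read by MTT assay, with a stated time of 24 h (on this read-out lower numbers stand for stronger inhibition and higher numbers for weaker inhibition), measured so far:

Compound 1 `O=C(O)CN1C(=O)/C(=C/c2ccc(OCC(=O)Nc3cccc(Cl)c3)cc2)SC1=S`: > 80000 nM, a limit of the assay.
Compound 2 `COCN1C(=O)S/C(=C\c2ccc(OCC(=O)Nc3cccc(Cl)c3)cc2)C1=O`: 68400 nM.
Compound 3 `O=C(COc1ccc(/C=C2\NC(=O)N(Cc3ccccc3)C2=O)cc1)Nc1cccc(Cl)c1`: > 80000 nM, a limit of the assay.

Among the measured compounds shown here, compound 2 is the only member of the series with an actual number in this assay; compound 1 and compound 3 sit at the limit of > 80000 nM in this assay, at which 2 of the 3 values shown sit, so no step between measured compounds can be read. Compound 4 `CC(CN(C)C)CN1C(=O)S/C(=C\c2ccc(OCC(=O)Nc3cccc(Cl)c3)cc2)C1=O` differs from compound 2 by 1-((dimethylamino)methyl)ethyl in place of methoxy on a saturated chain carbon bound to an amide-type nitrogen in a ring. For the measured compounds named here, with no measured step to lean on, the expected change is a 1.4-fold lower number from compound 2 to compound 4 (0.14 log units; within the scatter), a modest shift toward stronger inhibition but not clearly beyond the scatter. Compound 4 is therefore estimated at 50000 nM, with a range from 15000 nM to 120000 nM, and a real chance that only a limit is reported.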

Compound 4, half-maximal inhibitory concentration: > 80000 nM
Compound 4 gave a limit, no number (the forecaster's own chance of this, stated with the estimate: 35%); middle value at least 1.6-fold (0.20 log units) from the limit.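

In this assay, this position now has its first step, an at least 1.1-fold higher number from compound 2 to compound 4 (0.06 log units; that floor lies within the scatter), with 1-((dimethylamino)methyl)ethyl in place of methoxy on a saturated chain carbon bound to an amide-type nitrogen in a ring. The larger group brings no stronger inhibition, though the true size of the step cannot be read. Compound 4 gives > 80000 nM, a limit of the assay and not a number. The series still offers few numbers: the limit of > 80000 nM in this assay, at which 3 of the 4 values shown sit.

On these data alone, whether anything in this place gives a number clearly lower than that of compound 2 stays open. A primary amine or a longer unbranched alkyl chain here remains untested among the compounds shown, in this assay.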